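The source may report more compounds than this note shows. Statements on the series, on what has been measured and on what is new or still open speak of the compounds shown alone.

Measured compounds:
compound 1 `N#CC1=C(N)N(c2ccc(S(N)(=O)=O)cc2)C2=C(C(=O)CCC2)C1c1ccccc1`, 40%
compound 2 `Cc1ccc(C2C(C#N)=C(N)N(c3ccc(S(N)(=O)=O)cc3)C3=C2C(=O)CCC3)cc1`, 50%
compound 3 `N#CC1=C(N)N(c2ccc(S(N)(=O)=O)cc2)C2=C(C(=O)CCC2)C1c1ccco1`, 5%

In a functional assay on Ehrlich cells (Mus musculus) for antiproliferative activity, read by trypan blue exclusion, with a stated time of 2 h, tested at 50 ug/mL (a lower number here means a weaker effect, a higher number a stronger effect of the compound at the concentration tested), compound 1 gives 40% and compound 2 gives 50%. The two differ by methyl in place of hydrogen on an aromatic carbon, a change that made a number 10 percentage points higher from compound 1 to compound 2 (within the scatter). Compound 3 differs from compound 1 by furan-2-yl in place of phenyl on a saturated ring carbon. In this assay compound 3 gives 5%, with a number 35 percentage points lower from compound 1 to compound 3 (beyond the scatter) and a number 45 percentage points lower from compound 2 to compound 3 (beyond the scatter).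

Compound 4 `Cc1ccoc1C1C(C#N)=C(N)N(c2ccc(S(N)(=O)=O)cc2)C2=C1C(=O)CCC2` has not been measured. It differs from compound 3 by methyl in place of hydrogen on an aromatic carbon. Among the measured compounds shown here, this is the same kind of change as the one from compound 1 to compound 2, not the same: there the methyl enters on a six-membered aromatic ring of carbon only, para to a large group; here on a five-membered aromatic ring with 1 oxygen, next to the ring atom that bears a large group, two ring bonds from the ring oxygen. Because the earlier step was a number 10 percentage points higher from compound 1 to compound 2 (within the scatter), only a small step is expected from compound 3 to compound 4, estimated as a number 7 percentage points higher from compound 3 to compound 4 (within the scatter). Compound 4 is therefore estimated at 12%, expected between 0% and 30%.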

Compound 4, a percentage reported as activity, at one concentration (the size of the read-out at that concentration, not a potency): 40%
Beside the measured number, compound 4's estimate is 28 percentage points below it; measured number outside the range, above it.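

Methyl on the furan ring gives a number 35 percentage points higher from compound 3 to compound 4 (beyond the scatter) in this assay and brings compound 4 level with the two compounds that carry a six-membered aromatic ring, with a number 10 percentage points lower from compound 2 to compound 4 (within the scatter) and no change at the digits printed from compound 1 to compound 4 (within the scatter) on the exchange of those rings. Two pairs cannot tell whether the ring itself or the place of the methyl on it sets the size of the step, and they give no rule for a further core. What they do show is that the size of the step did not carry over from one core to the other: the same change on two cores in this assay, a number 10 percentage points higher (within the scatter) from compound 1 to compound 2 and a number 35 percentage points higher (beyond the scatter) from compound 3 to compound 4, 25 percentage points apart, beyond the scatter of two such steps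

The compounds shown leave open how an amine, a methoxy group or a carboxylic acid on the furan ring would read in this assay and whether methyl elsewhere on that ring gives a step of the same size.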